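The source may report more compounds than this note shows. Statements on the series, on what has been measured and on what is new or still open speak of the compounds shown alone.

Working notes on the chalcone set in a functional assay on HCT-116 cells (Homo sapiens), read by fluorescence and BrdU incorporation, with a stated time of 48 h, tested at 10 uM; on this read-out higher numbers stand for a weaker effect at the one concentration tested and lower numbers for a stronger effect.

Compound 3 `COc1cc(OC)c(C(=O)/C=C/c2ccc(F)cc2)c(OC)c1` gives 23% in this assay. Compound 1 `COc1cc(OC)c(C(=O)/C=C/c2ccccc2SC)c(OC)c1` gives 25% and compound 2 `COc1cccc(/C=C/C(=O)c2c(OC)cc(OC)cc2OC)c1` gives 20%; the three numbers lie within the scatter of one another, compound 3 sitting as the second highest of the three, with compound 1 as its nearest neighbour and compound 2 as its furthest.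

Compound 4 `COc1cc(OC)c(C(=O)/C=C/c2ccc(Br)cc2)c(OC)c1` differs from compound 3 only in the aryl ring carried on the double-bonded chain carbon: bromo in place of fluoro on an aromatic carbon. For the measured compounds named here, no measured step swaps one halogen for another. Going by the values given here, the steps that bear on this position are the ring-substituent exchanges a number 2 percentage points lower from compound 1 to compound 3 (within the scatter) and a number 3 percentage points higher from compound 2 to compound 3 (within the scatter), both within the scatter, as is a number 5 percentage points lower from compound 1 to compound 2 (within the scatter). Across a methylsulfanyl, a methoxy and a fluoro group this aryl position has moved the number very little, so the bromo group is expected to give a step of about no change at the digits printed from compound 3 to compound 4 (within the scatter) in this assay, that is, none beyond the scatter.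

Compound 4 is therefore estimated at 23% in this assay, within a range of 10% to 40%.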

Compound 4, a percentage reported as activity, at one concentration (the size of the read-out at that concentration, not a potency): 68%
For compound 4 the middle estimate is 45 percentage points below the measured one, and the stated range ends below it.
By their numbers in this assay, from the lowest: compounds 2, 3 and 1 (each within the scatter of the next); then compound 4.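

For the compounds shown here, the aryl position is less indifferent in this assay than the earlier compounds suggested: bromo in place of fluoro on an aromatic carbon, para to a large group, gives a number 45 percentage points higher from compound 3 to compound 4 (beyond the scatter), while the exchanges among compound 1, compound 2 and compound 3 all stayed within the scatter. The 4-bromophenyl group also stands apart from the other two aryl groups, with a number 48 percentage points higher from compound 2 to compound 4 (beyond the scatter) and a number 43 percentage points higher from compound 1 to compound 4 (beyond the scatter), so the effect at the one concentration tested is clearly weaker with this one halogen exchange than with any earlier aryl group. Nothing available accounts for this step.

Open, on these data alone, is whether chloro or iodo at this place would read like fluoro or like bromo. Also open, as far as these compounds go, is how an amine or a carboxylic acid would read on this ring, and whether bromo elsewhere on the ring would give the same step.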